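This account rests on a few compounds, and the source may have more. Where it says the series, first, only, none or still open, it means among the compounds named here.

Three compounds share one core and differ only in the group on a saturated chain carbon bound to an amide-type nitrogen. In a functional assay on HCT-116 cells (Homo sapiens) for antiproliferative activity, read by MTT assay, with a stated time of 48 h (a lower number here means a stronger inhibitor, a higher number a weaker inhibitor), compound 1 `COc1ccc(CN(C(=O)CSc2nc3ccccc3s2)c2cc(OC)c(OC)c(OC)c2)cc1C` gives 17100 nM, compound 2 `COc1ccc(CN(C(=O)CSc2nc3ccccc3s2)c2cc(OC)c(OC)c(OC)c2)cc1N` gives 491 nM, and compound 3 `COc1cc(N(Cc2ccc(Br)cc2)C(=O)CSc2nc3ccccc3s2)cc(OC)c1OC` gives 63800 nM, the highest number of the three. Compound 4 `COc1ccc(CN(C(=O)CSc2nc3ccccc3s2)c2cc(OC)c(OC)c(OC)c2)cc1[N+](=O)[O-]` has not yet been measured; compared with compound 3 it carries 4-methoxy-3-nitrophenyl in place of 4-bromophenyl on a saturated chain carbon bound to an amide-type nitrogen. The comparisons that bear on this are the modest step of a 3.7-fold higher number from compound 1 to compound 3 (0.57 log units; beyond the scatter) and the large step of a 130-fold higher number from compound 2 to compound 3 (2.11 log units; beyond the scatter), both showing the 4-bromophenyl group with a higher number than the other two groups. A lower number is therefore expected for compound 4, with the step of a 16-fold lower number from compound 3 to compound 4 (1.20 log units; beyond the scatter) expected to fall between those two. Compound 4 is estimated at 4000 nM, within 800 nM to 20000 nM.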

Compound 4, half-maximal inhibitory concentration: 1280 nM
For compound 4 the middle estimate is 3.1-fold (0.49 log units) above the measured one; low and high end bracket the measured number.
By their numbers in this assay, from the lowest: compound 2; then compound 4; then compound 1; then compound 3.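

In this assay, nitro on the aromatic carbon that held methyl or amino gives a number close to that of the amino compound: nitro in place of methyl brings a 13-fold lower number from compound 1 to compound 4 (1.13 log units; beyond the scatter), while nitro in place of amino still costs a 2.6-fold higher number from compound 2 to compound 4 (0.42 log units; beyond the scatter). Against 4-bromophenyl, the 4-methoxy-3-nitrophenyl group brings a 50-fold lower number from compound 3 to compound 4 (1.70 log units; beyond the scatter), so among these four compounds the two with a nitrogen-bearing group on that carbon give the lowest numbers. No measurement here explains these differences. Still open, from the compounds shown here alone, is whether a hydroxyl or an acetamide on that carbon would give a number as low as amino does.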